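A few compounds are considered here, and "the series" means these few. Any claim that something is new, unique, unknown or untested is made for them only; others in the source may bear on it.

Measured so far:
compound 1, `C=C(C)c1ccccc1OC(C)C1=NCCN1`, in a functional assay on CHO cells for agonist activity at Alpha-2C adrenergic receptor (Homo sapiens) (a higher number here means that more compound is needed for the effect, a lower number that less compound is needed), compound 1 gives 115 nM
compound 2, `CC(C)Oc1ccccc1OC(C)C1=NCCN1`, compound 2 gives 100 nM
compound 3, `CC(Oc1ccccc1OC1CC1)C1=NCCN1`, compound 3 gives 47.9 nM

Compound 3 holds the lowest of the three numbers. Its nearest neighbour is compound 2: the step of a 2.1-fold lower number from compound 2 to compound 3 (0.32 log units; beyond the scatter) is modest but beyond the scatter. The step of a 2.4-fold lower number from compound 1 to compound 3 (0.38 log units; beyond the scatter) is of similar size. Between compound 1 and compound 2 the step of a 1.2-fold lower number from compound 1 to compound 2 (0.06 log units; within the scatter) lies within the scatter.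

The next compound, compound 4, `CC(Oc1ccccc1C=O)C1=NCCN1`, differs from compound 3 only in one place: formyl in place of cyclopropyloxy on an aromatic carbon.

Both measured steps that bear on this position, a 2.4-fold lower number from compound 1 to compound 3 (0.38 log units; beyond the scatter) and a 2.1-fold lower number from compound 2 to compound 3 (0.32 log units; beyond the scatter), moved the number down on arrival at cyclopropyloxy, each by a modest amount. Leaving cyclopropyloxy in the other direction is the untested case; no measured step brings formyl in, and neither of the groups that preceded cyclopropyloxy resembles it. The two known steps suggest that a group other than cyclopropyloxy at this carbon tends to sit somewhat higher, so a modest rise is expected: a 3.3-fold higher number from compound 3 to compound 4 (0.52 log units; beyond the scatter), with wide uncertainty because the step of a 2.1-fold lower number from compound 2 to compound 3 (0.32 log units; beyond the scatter) was itself modest. For compound 4 the expected value in this assay is 160 nM, estimated to fall between 50 nM and 600 nM.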

Compound 4, half-maximal effective concentration: 100 nM
Beside the measured number, compound 4's estimate is 1.6-fold (0.20 log units) above it; measured number inside the range.
By their numbers in this assay, from the lowest: compound 3; then compounds 2, 4 and 1 (each within the scatter of the next).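

In this assay, leaving cyclopropyloxy for formyl gives a 2.1-fold higher number from compound 3 to compound 4 (0.32 log units; beyond the scatter), a modest step of the same size as the one that links isopropoxy and cyclopropyloxy, so compound 3 now stands apart from a third group at this aromatic carbon. Formyl cannot be told apart from the two other groups, with no change at the digits printed from compound 2 to compound 4 (within the scatter) and a 1.2-fold lower number from compound 1 to compound 4 (0.06 log units; within the scatter), so isopropoxy, 1-methylethenyl and formyl form one band in this assay even though they differ in kind. Of the four groups, only cyclopropyloxy carries a three-membered ring, but no measurement at hand gives a reason for its separate position.

On these data alone, whether the lower number of compound 3 goes with the three-membered ring itself or with the whole oxygen-linked group remains open, and a cyclopropyl placed directly on the aromatic carbon, without the oxygen, would separate the two. As far as these compounds go, how an amine, a carboxylic acid or a cyclobutyloxy group at this carbon would compare with these four also remains open.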